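Moving the methyl group: 4-methylphenyl to 3-methylphenyl

This account rests on a few compounds, and the source may have more. Where it says the series, first, only, none or still open, it means among the compounds named here.

In a toxicity assay on Huh-7 cells (Homo sapiens) for cytotoxicity, read by CCK-8 assay, with a stated time of 24 h (on this read-out higher numbers stand for lower toxicity in this test and lower numbers for higher toxicity in this test), compound 1 `COc1c(OC)c(OC)c2c(=O)cc(-c3ccccc3)oc2c1-c1ccc(OC(F)(F)F)cc1` gives > 100000 nM as a limit of the assay and not a number. Compound 2 `Cc1ccc(-c2c(O)c(O)c(O)c3c(=O)cc(-c4ccccc4)oc23)cc1` gives > 100000 nM as a limit too, so its standing is known only as that limit. All that the measurements offer so far is the limit of > 100000 nM in this assay, at which 2 of the 2 values shown sit, and no exact number. Compound 3 `Cc1cccc(-c2c(O)c(O)c(O)c3c(=O)cc(-c4ccccc4)oc23)c1` differs from compound 2 by 3-methylphenyl in place of 4-methylphenyl on an aromatic carbon with the same atoms joined differently. Going by the values given here, no step between measured compounds is available to size this change. Resting on compound 2 at > 100000 nM as a limit, no step beyond the scatter is expected in this assay and no direction is foreseen. The estimated step of a number no higher from compound 2 to compound 3 (the limit leaves the size open) is thus expected to stay within the scatter. For compound 3 the estimate is 100000 nM with an expected range of 50000 nM to 200000 nM and the reading may again be only a limit.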

Compound 3, half-maximal cytotoxic concentration: > 100000 nM
Compound 3: a limit, no number (the forecaster's own chance of this, stated with the estimate: 85%); the middle value lies on the limit itself.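

No step from compound 2 to compound 3 can be read, as both readings are limits and not numbers: the limit of > 100000 nM in this assay, at which 3 of the 3 values shown sit.

Left open is whether 3-methylphenyl in place of 4-methylphenyl changes the reading in this assay at all, and how these compounds would rank on exact numbers.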